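Piperazine for methyl-diazepane on the benzamide ring of compound 1

This account rests on a few compounds, and the source may have more. Where it says the series, first, only, none or still open, it means among the compounds named here.

Measured so far:
- compound 1 `COc1cc(OC)c(Cl)c(-c2ccc3c(NC(=O)c4ccc(N5CCCN(C)CC5)cc4)n[nH]c3n2)c1Cl`: 1.3 nM
- compound 2 `COc1cc(C(=O)Nc2n[nH]c3nc(-c4c(Cl)c(OC)cc(OC)c4Cl)ccc23)ccc1N1CCN(C)CC1`: 15.6 nM
- compound 3 `COc1cc(OC)c(Cl)c(-c2ccc3c(NC(=O)c4ccc(N5CCN(C)CC5)cc4)nn(C)c3n2)c1Cl`: "not determined" (no result reported)

In a functional assay on NCI-H1581 cells (Homo sapiens) for antiproliferative activity, read by CCK-8 assay, with a stated time of 72 h (a lower number here means a stronger inhibitor, a higher number a weaker inhibitor), compound 1 gives 1.3 nM, the lowest of the two numbers available. The nearest measured neighbour, compound 2, gives 15.6 nM in this assay, a higher number that lies beyond the usual scatter; compound 2 differs from compound 1 in more than one place, so no single step can be read from that pair. Compound 3 carries a methyl on the core and has no reported number.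

The next compound, compound 4 `COc1cc(OC)c(Cl)c(-c2ccc3c(NC(=O)c4ccc(N5CCNCC5)cc4)n[nH]c3n2)c1Cl`, differs from compound 1 in one place: piperazin-1-yl in place of 4-methyl-1,4-diazepan-1-yl on an aromatic carbon. Going by the values given here, no measured pair in the set isolates this change, so the expectation rests on compound 1 alone. A modest weakening is expected, of a size that may stay within the scatter, since the anchoring of the amide and the core are untouched. The step from compound 1 to compound 4 is estimated at a 2.3-fold higher number from compound 1 to compound 4 (0.36 log units; beyond the scatter). Compound 4 is therefore expected to give about 3 nM in this assay, most likely between 1 nM and 10 nM.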

Compound 4, half-maximal inhibitory concentration: 1.4 nM
The estimate for compound 4 lay 2.1-fold (0.33 log units) above the measured number; the measured number falls inside the stated range.
By their numbers in this assay, from the lowest: compounds 1 and 4 (each within the scatter of the next); then compound 2.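

In this assay, going by these compounds alone, the first single change at this position gives a 1.1-fold higher number from compound 1 to compound 4 (0.03 log units; within the scatter), so on this aromatic carbon, para to a large group, piperazin-1-yl stands in for 4-methyl-1,4-diazepan-1-yl with no readable loss. The exchange alters ring size and replaces the methyl-bearing ring nitrogen with one carrying a hydrogen-bond donor, yet the pair cannot assign any share of the outcome to either feature, and the two differences may or may not offset each other. No measurement is available that bears on why the number holds here.

Still open, on these data alone, is how the unmethylated 1,4-diazepan-1-yl would read, since it would separate ring size from the methyl. Also open, as far as these compounds go, is whether a morpholin-4-yl ring or an open-chain dimethylamino group would be accepted at this place.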